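The compounds below may be only part of what the source reports. "The series", "measured", "known", "first", "only" and "open" are said of these compounds alone.

Compound 1 `O=C1NCCC12CCN(c1c(Cl)cncc1-c1ccsc1)CC2` is the smallest-numbered of the three measured compounds in a functional assay on MV4-11 cells (Homo sapiens) for inhibition, read by resazurin assay, with a stated time of 72 h; a higher number here means a weaker inhibitor of growth, a lower number a stronger inhibitor of growth: compound 1 gives 190 nM. Compound 2 `Cc1csc(-c2cncc(Cl)c2N2CCC3(CCNC3=O)CC2)c1` gives 650 nM in this assay, a step of a 3.4-fold higher number from compound 1 to compound 2 (0.53 log units; beyond the scatter). Compound 3 `CC(=O)c1ccc(-c2cncc(Cl)c2N2CCC3(CCNC3=O)CC2)s1` gives 1440 nM, a step of a 7.6-fold higher number from compound 1 to compound 3 (0.88 log units; beyond the scatter) and, from compound 2, a 2.2-fold higher number from compound 2 to compound 3 (0.35 log units; beyond the scatter).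

Compound 4 `O=C1NCCC12CCN(c1c(Cl)cncc1-c1cn[nH]c1)CC2` differs from compound 1 by 1H-pyrazol-4-yl in place of thiophen-3-yl on an aromatic carbon. Within the data shown here, no measured step exchanges the thiophen-3-yl for a ring with 2 hetero atoms or introduces a hydrogen-bond donor at this carbon; the two measured steps from compound 1, a 3.4-fold higher number from compound 1 to compound 2 (0.53 log units; beyond the scatter) and a 7.6-fold higher number from compound 1 to compound 3 (0.88 log units; beyond the scatter), only vary the thiophene and both weaken growth inhibition modestly. This assay therefore gives no direct guide, and it is estimated that compound 4 lies close to compound 1 with a wide range, an expected step of a 1.6-fold higher number from compound 1 to compound 4 (0.20 log units; within the scatter). Compound 4 is expected to give 300 nM in this assay, between 80 nM and 1200 nM.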

Compound 4, concentration for 50% growth inhibition: 8520 nM
The estimate for compound 4 lay 28-fold (1.45 log units) below the measured number; the whole stated range lies below it.
By their numbers in this assay, from the lowest: compound 1; then compound 2; then compound 3; then compound 4.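

In this assay this aromatic carbon proves far less forgiving of a change of ring than the thiophene variations had shown: 1H-pyrazol-4-yl in place of thiophen-3-yl, with the same count of heavy atoms, gives a 45-fold higher number from compound 1 to compound 4 (1.65 log units; beyond the scatter) as the largest step in the set. The pyrazole compound also falls behind both substituted thiophenes, with a 13-fold higher number from compound 2 to compound 4 (1.12 log units; beyond the scatter) and a 5.9-fold higher number from compound 3 to compound 4 (0.77 log units; beyond the scatter) so that even the 5-acetylthiophen-2-yl group is better accepted here. Nothing at hand explains this loss of growth inhibition.

The change replaces sulfur with two nitrogens and adds a hydrogen-bond donor, and the compounds shown do not separate these differences. From the compounds shown here alone, it also remains open how a 1-methyl-1H-pyrazol-4-yl or a phenyl group on this carbon would compare with thiophen-3-yl.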